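Swapping a neopentyl end for an unsaturated one on an amide

The source may report more compounds than this note shows. Statements on the series, on what has been measured and on what is new or still open speak of the compounds shown alone.

Three related compounds have been measured in a physicochemical assay for lipophilicity; a lower number here means a more polar compound, a higher number a more lipophilic compound. Compound 1, `CCOC(=O)/C=C(C)/C=C/CC(C)CCCC(C)(C)C`, an ethyl ester, gives 7.15 in this assay. Compound 2, `CCOC(=O)/C=C(C)/C=C/CC(C)CCC=C(C)C`, keeps the ester but carries a different chain end: 2-methylprop-1-en-1-yl in place of neopentyl on a saturated chain carbon, four bonds along the chain from a double-bonded chain carbon. That change produced a number 0.96 log units lower from compound 1 to compound 2 (beyond the scatter). Compound 3, `CCNC(=O)/C=C(C)/C=C/CC(C)CCCC(C)(C)C`, differs from compound 1 at the carbonyl carbon instead: ethylamino in place of ethoxy on a carbonyl carbon. Here the step was a number 1.50 log units lower from compound 1 to compound 3 (beyond the scatter), and compound 3 gives 5.65 in this assay, the lowest of the three numbers, with compound 2 at 6.19 standing nearest to it.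

Compound 4, `CCNC(=O)/C=C(C)/C=C/CC(C)CCC=C(C)C`, has not yet been measured. It relates to compound 3 exactly as compound 2 relates to compound 1: 2-methylprop-1-en-1-yl in place of neopentyl on a saturated chain carbon, four bonds along the chain from a double-bonded chain carbon. The place is the same in both cases, on a saturated chain carbon four bonds along the chain from a double-bonded chain carbon, so this is the same change, only made on a different core; the two cores differ by the ethylamino group in place of ethoxy on the carbonyl carbon described above.

Among the measured compounds shown here, the step is expected to be a number 0.96 log units lower from compound 3 to compound 4 (beyond the scatter) in this assay, resting on the single earlier example of the same change, which gave a number 0.96 log units lower from compound 1 to compound 2 (beyond the scatter). Compound 4 is therefore expected to give about 4.69 in this assay. Compound 4 is estimated to fall between 4.25 and 5.1, with the width allowing for the change having been seen only once and on another core.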

Compound 4, partition coefficient: 4.69
Beside the measured number, compound 4's estimate shows no gap at the digits printed; low and high end bracket the measured number.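

In this assay, putting 2-methylprop-1-en-1-yl in place of neopentyl gave a number 0.96 log units lower from compound 3 to compound 4 (beyond the scatter) and so matched the earlier a number 0.96 log units lower from compound 1 to compound 2 (beyond the scatter) on the core of compound 1; the change carried over to the second core at the same size. The other change reads the same way, since ethylamino in place of ethoxy gave a number 1.50 log units lower from compound 2 to compound 4 (beyond the scatter) whichever chain end was present, as in the earlier a number 1.50 log units lower from compound 1 to compound 3 (beyond the scatter), and across these four compounds the two changes simply add. Among the compounds shown here, this rests on only two cores, so it does not show that the change would keep its size on any further core, and nothing measured here explains why the steps agree.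

The change removes one carbon and brings in a double bond at the same time, so the compounds shown leave open how much of the step belongs to each, something a saturated 2-methylpropyl end could help to separate. They also leave open whether the two changes would still add with a carboxylic acid on the carbonyl carbon, or with a longer chain.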